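Fluoro for methyl on the aryl ring of two amide cores

A few compounds are considered here, and "the series" means these few. Any claim that something is new, unique, unknown or untested is made for them only; others in the source may bear on it.

Of the compounds shown here, three have been measured in a functional assay on HeLa cells (Homo sapiens) for cytotoxicity, read by CCK-8 assay, with a stated time of 24 h (a higher number here means a weaker inhibitor, a lower number a stronger inhibitor), and none of them has given a number. Compound 1 `C/C(=C\c1cc(-c2ccc(C)nc2)co1)C(N)=O` carries a methyl group on its six-membered aromatic ring with 1 nitrogen. In this assay compound 1 reaches only the limit > 50000 nM. Compound 2 `C/C(=C\c1cc(-c2ccc(F)nc2)co1)C(N)=O` is its fluoro counterpart, differing by fluoro in place of methyl on an aromatic carbon. In this assay compound 2 also stops at the limit > 50000 nM. The step that the two limits leave unreadable from compound 1 to compound 2 therefore cannot be read, since both ends sit at the limit of > 50000 nM in this assay, at which 3 of the 3 values shown sit.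

Compound 3 `C/C(=C\c1cc(-c2ccc(C)cc2)cs1)C(N)=O` has a different core; how the two cores differ is not broken down here. In this assay compound 3 likewise returns the limit > 50000 nM.

Compound 4 `C/C(=C\c1cc(-c2ccc(F)cc2)cs1)C(N)=O` has not yet been measured. It differs from compound 3 by fluoro in place of methyl on an aromatic carbon. This is the same kind of change as that from compound 1 to compound 2, but the surroundings differ: in compound 1 the place is on a six-membered aromatic ring with 1 nitrogen, next to the ring nitrogen; in compound 3 it is on a six-membered aromatic ring of carbon only, in both cases para to a large group.

Since compound 1, compound 2 and compound 3 all sit at the limit of > 50000 nM in this assay, at which 3 of the 3 values shown sit, the step that the limit leaves unreadable from compound 3 to compound 4 is expected to be unreadable as well. Compound 4 is estimated to lie at about 80000 nM, most likely again as a limit rather than a number.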

Compound 4, half-maximal inhibitory concentration: 20800 nM
Compound 4: middle estimate off by 3.8-fold (0.59 log units), on the high side, outside the stated range (below it).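

In this assay, going by these compounds, fluoro in place of methyl on an aromatic carbon of the six-membered aromatic ring of carbon only, para to a large group, gives an at least 2.4-fold lower number from compound 3 to compound 4 (0.38 log units; beyond the scatter), and the true size of this step stays open, as its starting end is a limit and not a number. This shows that the change can lower the number on one core, and compound 4 is the only compound shown that gives a number at all. It does not show that the change carries from one core to another, as the matching step on the core of compound 1 cannot be read, with a limit at both of its ends: the limit of > 50000 nM in this assay, at which 3 of the 4 values shown sit.

One readable step on one core is therefore no pattern, and the result says nothing about how much the core itself contributes. The compounds shown leave open whether a chloro or a trifluoromethyl group in the same place would also give a number in this assay, and whether the step would hold on the core of compound 1 if a value could be read there. They also leave open what a carboxylic acid or an amine in place of the amide would do on the core of compound 4.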